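Replacing the 4-chlorophenyl group of compound 2

The source may report more compounds than this note shows. Statements on the series, on what has been measured and on what is new or still open speak of the compounds shown alone.

In a functional assay on A2780 cells (Homo sapiens) for antiproliferative activity, read by MTT assay, with a stated time of 72 h (on this read-out higher numbers stand for weaker inhibition and lower numbers for stronger inhibition), compound 1 `O=C(c1cc2ccccc2o1)N1N=C(c2ccccc2)CC1c1ccc(Cl)cc1` gives 5.13 ug/mL. Compound 2 `O=C(c1cc2ccccc2o1)N1N=C(c2ccc(F)cc2)CC1c1ccc(Cl)cc1` gives > 50 ug/mL, which is a limit of the assay and not a number. Compound 2 thus stands at the limit of > 50 ug/mL in this assay, at which 1 of the 2 values shown sits. Among the compounds with values here, the one measured step is an at least 9.7-fold higher number from compound 1 to compound 2 (0.98 log units; beyond the scatter), which lies beyond the scatter and comes with fluoro in place of hydrogen on an aromatic carbon.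

Compound 3 `COc1ccc(C2CC(c3ccc(F)cc3)=NN2C(=O)c2cc3ccccc3o2)cc1OC` has 3,4-dimethoxyphenyl in place of 4-chlorophenyl on a saturated ring carbon. Within the data shown here, the measured step lies elsewhere in the molecule, so no measured step covers this place, and it serves only as a guide to how far one change can move the read-out. Resting on the limit of compound 2 at > 50 ug/mL, the expected direction in this assay is toward stronger inhibition or no readable change, and the expected size is smaller than the measured step. The estimated step is an at least 1.4-fold lower number from compound 2 to compound 3 (0.15 log units; that floor lies within the scatter). Compound 3 is expected at 35 ug/mL, with an estimated range of 10 ug/mL to 100 ug/mL.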

Compound 3, half-maximal inhibitory concentration: > 50 ug/mL
Compound 3 was reported as a limit; the forecaster's own chance of this, stated with the estimate: 50%; middle value at least 1.4-fold (0.15 log units) from the limit.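

Compound 2 and compound 3 both stand at a limit of the assay and not at a number, so no step between them can be read in this assay: the limit of > 50 ug/mL in this assay, at which 2 of the 3 values shown sit.

The compounds shown leave open whether 3,4-dimethoxyphenyl in place of 4-chlorophenyl on a saturated ring carbon changes the read-out at all, including on the core of compound 1.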